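Trifluorophenyl tail placed on the methylated core

A few compounds are considered here, and "the series" means these few. Any claim that something is new, unique, unknown or untested is made for them only; others in the source may bear on it.

Two measured compounds, compound 1 `O=C(O)CCCc1cn(CC(=O)O)c2c(/C=C/c3ccc(OCCCCc4c(F)ccc(F)c4F)cc3)cccc12` and compound 2 `Cc1c(CCCC(=O)O)c2cccc(/C=C/c3ccc(OCCCCc4cc(F)c(F)c(F)c4F)cc3)c2n1CC(=O)O`, share the ether-linked tail ending in a fluorinated phenyl ring but differ in their cores. In a functional assay on HEK293 cells for antagonist activity at cysteinyl leukotriene receptor 2 (Homo sapiens), read by fluorescence and calcium flux, with stated times of 30 min and 1 h (on this read-out lower numbers stand for stronger inhibition and higher numbers for weaker inhibition), compound 1 gives 2.1 nM and compound 2 gives 1.5 nM, the lower of the two numbers, the gap to compound 1 lying within the scatter. Compound 3 is `Cc1c(CCCC(=O)O)c2cccc(/C=C/c3ccc(OCCCCc4c(F)ccc(F)c4F)cc3)c2n1CC(=O)O`, the core of compound 2 carrying (2,3,6-trifluorophenyl in place of 2,3,4,5-tetrafluorophenyl on a saturated chain carbon, four bonds along the chain from an oxygen on an aromatic ring). The step of a 1.2-fold higher number from compound 2 to compound 3 (0.08 log units; within the scatter) is expected to stay within the scatter, because compound 1 with that same ring gives 2.1 nM close to compound 2. Compound 3 is therefore estimated at 1.8 nM, with a range from 0.8 nM to 4 nM.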

Compound 3, half-maximal inhibitory concentration in the cysteinyl leukotriene receptor 2 assay: 1 nM
For compound 3 the middle estimate is 1.8-fold (0.26 log units) above the measured one; measured number inside the range.
By their numbers in the cysteinyl leukotriene receptor 2 assay, from the lowest: compounds 3, 2 and 1 (each within the scatter of the next, the first and the last beyond it).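

In the cysteinyl leukotriene receptor 2 assay, the ring exchange at this position on the shared core gives a 1.5-fold lower number from compound 2 to compound 3 (0.18 log units; within the scatter), so that read-out does not separate the two fluorinated rings. With the 2,3,6-trifluorophenyl tail held constant, the cysteinyl leukotriene receptor 2 assay shows a 2.1-fold lower number from compound 1 to compound 3 (0.32 log units; beyond the scatter) for methyl in place of hydrogen on an aromatic carbon, a modest step. In a physicochemical assay for permeability, using PAMPA, with a stated time of 4 h, at pH 6.2, tested at 50 uM (a higher number here means that the compound crosses the layer faster, a lower number that the compound crosses the layer more slowly), compound 2 gives 1.8 10^-6 cm/s and compound 3 gives 4.4 10^-6 cm/s, a gap beyond the scatter that the two rings do not show at the receptor.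

Open, as far as these compounds go, is how a pyridine ring or a longer chain at this place would read, and whether the methyl step holds with the 2,3,4,5-tetrafluorophenyl tail.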